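The source may report more compounds than this note shows. Statements on the series, on what has been measured and on what is new or still open speak of the compounds shown alone.

Of the compounds shown here, three built on the shared core have been measured in an assay on isolated protein for inhibition of Amine oxidase [flavin-containing] B (Bos taurus); a higher number here means a weaker inhibitor, a lower number a stronger inhibitor. Compound 1, with structure `CCC(=O)N1N=C(c2ccccc2)CC1c1ccc(F)cc1`, gives 1150 nM in this assay. Compound 3, with structure `CCC(=O)N1N=C(c2ccc(F)cc2)CC1c1ccccc1`, gives 200 nM. Compound 2, with structure `CCC(=O)N1N=C(c2ccc(Cl)cc2)CC1c1ccc(Cl)cc1`, gives 10000 nM, the highest of the three numbers: the gap to compound 1 is the nearest, and the gap to compound 3 is the widest, both beyond the usual scatter. No two of these compounds differ in only one place, so the numbers alone show the ordering and no single change can be read off.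

Compound 4, with structure `CCC(=O)N1N=C(c2ccc(OC)cc2)CC1c1ccc(Cl)cc1`, is not yet measured. It differs from compound 2 by methoxy in place of chloro on an aromatic carbon. Going by the values given here, no measured pair shows this exchange. Because compound 2 sits at 10000 nM while compound 1 and compound 3 lie well lower, a moderate step downward in this assay is expected, estimated as a 2.0-fold lower number from compound 2 to compound 4 (0.30 log units; within the scatter). Compound 4 is thus expected to give about 5000 nM, within a range from 1500 nM to 15000 nM.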

Compound 4, half-maximal inhibitory concentration: 851 nM
Estimate against measurement, compound 4: 5.9-fold (0.77 log units) above; the whole stated range lies above it.
By their numbers in this assay, from the lowest: compound 3; then compounds 4 and 1 (each within the scatter of the next); then compound 2.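

In this assay, going by these compounds alone, methoxy in place of chloro on the aromatic carbon para to a large group gives a 12-fold lower number from compound 2 to compound 4 (1.07 log units; beyond the scatter), and this is the first change that can be read on its own. It shows that this position is not indifferent: with the rest of the structure held constant, the exchange of 4-chlorophenyl for 4-methoxyphenyl moves the number by a large step, beyond the scatter. The high number of compound 2 therefore depends on this one group, even with the other chloro left in place. Nothing at hand accounts for the size of this step. As far as these compounds go, whether a hydroxy group, an ethoxy group or an amine at this position would give a similar step stays open, as does the question of whether the same exchange would carry the same size on a compound lacking the other chloro.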